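Swapping phenylsulfonyl for phenoxycarbonyl on an inactive compound

The source may report more compounds than this note shows. Statements on the series, on what has been measured and on what is new or still open speak of the compounds shown alone.

compound 1 `CC(C)=CCC/C(C)=C/CC/C(C)=C/CC[C@]1(C)CCc2c(C)c(OC(=O)NS(=O)(=O)c3ccccc3)c(C)c(C)c2O1` gives > 10000 nM (a limit)
compound 2 `CC(C)=CCC/C(C)=C/CC/C(C)=C/CC[C@]1(C)CCc2cc(OC(=O)NS(=O)(=O)c3ccccc3)c(C)c(C)c2O1` gives > 10000 nM (a limit)
compound 3 `CC(C)=CCC/C(C)=C/CC/C(C)=C/CC[C@]1(C)CCc2cc(OC(=O)NC(=O)Oc3ccccc3)cc(C)c2O1` gives "not determined" (no result reported) (no number)

In a functional assay on MDA-MB-231 cells (Homo sapiens) for antiproliferative activity, read by MTT assay, with a stated time of 96 h (a higher number here means a weaker inhibitor, a lower number a stronger inhibitor), compound 1 gives > 10000 nM as a limit of the assay and not a number. Compound 2 gives > 10000 nM as a limit too. Each of these readings is the limit of > 10000 nM in this assay, at which 2 of the 3 values shown sit, in the data so far. The unmeasured compound 4 `CC(C)=CCC/C(C)=C/CC/C(C)=C/CC[C@]1(C)CCc2c(C)c(OC(=O)NC(=O)Oc3ccccc3)c(C)c(C)c2O1` differs from compound 1 as follows: phenoxycarbonyl in place of phenylsulfonyl on an amide-type nitrogen in short, phenoxycarbonyl in place of phenylsulfonyl on an amide-type nitrogen. Going by the values given here, the only measured step is a step that the two limits leave unreadable from compound 1 to compound 2 and it concerns another change, so it offers no size to carry over. Compound 3 also bears phenoxycarbonyl on an amide-type nitrogen, but it has no result. The expectation therefore rests on compound 1 with its limit of > 10000 nM as the only anchor. What is expected in this assay is a number no higher from compound 1 to compound 4 (the limit leaves the size open) with no firm direction. For compound 4 the estimated value is 10000 nM with an expected range from 3000 nM to 30000 nM in this assay.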

Compound 4, half-maximal inhibitory concentration: > 10000 nM
Compound 4: no number, only a limit (the forecaster's own chance of this, stated with the estimate: 60%); the middle value sits exactly at the limit.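

In this assay compound 1 and compound 4 each give only a limit and not a number, so no step can be read for phenoxycarbonyl in place of phenylsulfonyl: the limit of > 10000 nM in this assay, at which 3 of the 4 values shown sit.

The compounds shown leave open whether either group on the amide-type nitrogen changes the activity at all.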